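This account rests on a few compounds, and the source may have more. Where it says the series, first, only, none or still open, it means among the compounds named here.

Working notes on a small set sharing one core, tested in a functional assay on A549 cells (Homo sapiens) for cytotoxicity, read by MTT assay, with a stated time of 24 h; on this read-out lower numbers stand for stronger inhibition and higher numbers for weaker inhibition. Within the data shown here, compound 1 `CC1(C)OC2O[C@@H](Cc3cn4cc(Cl)ccc4nc3=O)C(OCc3ccccc3)C2O1` gives 182000 nM in this assay, the only number measured in this set so far, so it stands alone without a neighbour to rank it against. Compound 2 `O=c1nc2ccc(Cl)cn2cc1Cc1ccc(F)cc1C(F)(F)F` returns only > 1000000 nM in this assay, which is a limit of the assay and not a number. That is the limit of > 1000000 nM in this assay, at which 1 of the 2 values shown sits. Among the measured compounds shown here, no step between measured compounds is available, so nothing measured here sets a scale for any change on the core.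

Compound 3 `CC1(C)OC2O[C@@H](Cc3cn4ccccc4nc3=O)C(OCc3ccccc3)C2O1` is the next one to be measured in this assay. Against compound 1 the change is hydrogen in place of chloro on an aromatic carbon; the side chain and the rest of the core stay as they are. For the measured compounds named here, no measured pair here shows what the chloro leaving does, so the expectation rests on the single number of compound 1 and on the size of change one usually sees for a small substituent. The expected step is a 1.4-fold higher number from compound 1 to compound 3 (0.15 log units; within the scatter), most likely a mild weakening, possibly none beyond the scatter. Compound 3 is estimated at 260000 nM in this assay, with a range from 90000 nM to 750000 nM, and some chance that only a limit is returned.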

Compound 3, half-maximal inhibitory concentration: 199000 nM
Beside the measured number, compound 3's estimate is 1.3-fold (0.12 log units) above it; measured number inside the range.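

In this assay, the first step available on this series reads a 1.1-fold higher number from compound 1 to compound 3 (0.04 log units; within the scatter), so removing the chloro leaves the number where it was within the usual scatter. Among these compounds, this is the first measured sign of how much this position matters: on this aromatic carbon, two atoms from the ring nitrogen, hydrogen and chloro cannot be told apart in this read-out, and the chloro is not required for the activity seen in compound 1. The pair sets no order between compound 1 and compound 3, and nothing measured here gives a reason for the outcome of this single exchange.

As far as these compounds go, only hydrogen and chloro have been compared at this carbon, so the effect of a methoxy group, an amine or a carboxylic acid there remains open, as does any wider reading of this position from a single pair. Compound 2 differs from compound 1 in more than one place, so no step to it can be read, and its value is a limit of the assay and not a number: the limit of > 1000000 nM in this assay, at which 1 of the 3 values shown sits.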